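Methyl for hydrogen on a phenolic oxygen at the assay limit

The source may report more compounds than this note shows. Statements on the series, on what has been measured and on what is new or still open speak of the compounds shown alone.

Compound 1 `CCCOc1c(O)cc2oc(-c3ccccc3)cc(=O)c2c1O` and compound 2 `CCCOc1c(OC)cc2oc(-c3ccccc3)cc(=O)c2c1O` share a core, and compound 2 differs from it in one place: methyl in place of hydrogen on an oxygen on an aromatic ring. In a functional assay on KB 3-1 cells (Homo sapiens) for inhibition, with a stated time of 72 h (on this read-out higher numbers stand for weaker inhibition and lower numbers for stronger inhibition), compound 1 gives only a limit of the assay, > 100000 nM. In this assay compound 2 likewise gives only a limit, > 100000 nM. The step that the two limits leave unreadable from compound 1 to compound 2 therefore cannot be read, because of the limit of > 100000 nM in this assay, at which 3 of the 3 values shown sit. Compound 3 `CCCCCCOc1cc2oc(-c3ccccc3)cc(=O)c2c(O)c1OCCCCCC` rests on a different core; the difference between the two cores is not broken down here. In this assay compound 3 also gives only a limit, > 100000 nM. Compound 4 `CCCCCCOc1cc2oc(-c3ccccc3)cc(=O)c2c(OC)c1OCCCCCC` differs from compound 3 by the same change: methyl in place of hydrogen on an oxygen on an aromatic ring. For compound 4 the author expects a step that the limit leaves unreadable from compound 3 to compound 4, resting on the unreadable earlier step, and estimates its value in this assay at 200000 nM, between 50000 nM and 1000000 nM.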

Compound 4, half-maximal inhibitory concentration: 44800 nM
Beside the measured number, compound 4's estimate is 4.5-fold (0.65 log units) above it; measured number below the stated range.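

In this assay the change from hydroxy to methoxy gives an at least 2.2-fold lower number from compound 3 to compound 4 (0.34 log units; beyond the scatter), so on the core of compound 3 methyl in place of hydrogen on an oxygen on an aromatic ring goes with stronger inhibition, and the true size of this step is left open by the limit on one side. For the compounds shown here, this does not show that the change carries from one core to the other, as the one step is all that can be read. The same change on the core of compound 1 cannot be read: the limit of > 100000 nM in this assay, at which 3 of the 4 values shown sit.

The compounds shown leave open whether the same change lowers the number on the core of compound 1 at all. They also leave open how an amine or a carboxylic acid in place of the methyl would read in this assay on either core.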